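Swapping ethyl for ethylcarbamoyl on the ring amine nitrogen

The source may report more compounds than this note shows. Statements on the series, on what has been measured and on what is new or still open speak of the compounds shown alone.

In an in vitro ADME assay on microsomes from liver (Homo sapiens) for pharmacokinetics, read by LC-MS, with a stated time of 10 min, tested at 1 uM (on this read-out lower numbers stand for slow clearance and higher numbers for fast clearance), compound 1 `CN1C[C@H](C(=O)Nc2cccc(F)c2)[C@@H](c2ccc(/C=C/C(=O)Nc3ccccc3N)cc2)C1` gives 6 mL/min/kg and compound 2 `CN1C[C@H](C(=O)Nc2ccc(Cl)cc2F)[C@@H](c2ccc(/C=C/C(=O)Nc3ccccc3N)cc2)C1` gives 11 mL/min/kg while compound 3 `CCN1C[C@H](C(=O)Nc2ccc(Cl)cc2)[C@@H](c2ccc(/C=C/C(=O)Nc3ccccc3N)cc2)C1` gives 12 mL/min/kg and so stands within the usual scatter of both. Compound 4 `CCNC(=O)N1C[C@H](C(=O)Nc2ccc(Cl)cc2)[C@@H](c2ccc(/C=C/C(=O)Nc3ccccc3N)cc2)C1` differs from compound 3 by ethylcarbamoyl in place of ethyl on an amine nitrogen in a ring with ethylcarbamoyl in place of ethyl on an amine nitrogen in a ring. Within the data shown here, the one measured step in a single place is a 1.8-fold higher number from compound 1 to compound 2 (0.26 log units; within the scatter) and it lies within the scatter on an amide-type nitrogen, so it says little here, and no measured step touches the ring amine nitrogen. No shift beyond the scatter is therefore expected in this assay and the estimated change is a 1.2-fold lower number from compound 3 to compound 4 (0.08 log units; within the scatter) as a rough expectation. The estimate for compound 4 is 10 mL/min/kg with 4 mL/min/kg to 24 mL/min/kg as the expected range.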

Compound 4, clearance: 9 mL/min/kg
Compound 4: the middle estimate sits 1.1-fold (0.05 log units) above what was measured; measured number inside the range.
By their numbers in this assay, from the lowest: compounds 1, 4, 2 and 3 (each within the scatter of the next).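

The ring amine nitrogen, two ring bonds from the ring atom that bears the (4-chlorophenyl)carbamoyl group, now has its first measured step: in this assay, ethylcarbamoyl in place of ethyl gives a 1.3-fold lower number from compound 3 to compound 4 (0.12 log units; within the scatter). This larger group, carrying a hydrogen-bond donor and acceptor that ethyl lacks, therefore leaves the clearance reading within the scatter on this core. No other measurement here bears on this result. From the compounds shown here alone, it remains open whether an acetyl group, a carboxylic acid or a longer chain on this nitrogen would also leave the reading within the scatter.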